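A Repeated Amino Addition on Two Related Cores

The compounds below may be only part of what the source reports. "The series", "measured", "known", "first", "only" and "open" are said of these compounds alone.

Compound 1 `ClCc1ccc(Cn2cnc3c(Cl)ncnc32)cc1` and compound 2 `Nc1nc(Cl)c2ncn(Cc3ccc(CCl)cc3)c2n1` differ in a single place: amino in place of hydrogen on an aromatic carbon. In a functional assay on LOX IMVI cells (Homo sapiens) for cytotoxicity, read by sulforhodamine B assay, with a stated time of 48 h (a higher number here means a weaker inhibitor of growth, a lower number a stronger inhibitor of growth), compound 1 gives 1000 nM, while compound 2 gives 5370 nM, so that a 5.4-fold higher number from compound 1 to compound 2 (0.73 log units; beyond the scatter). Compound 3 `ClCc1ccccc1Cn1cnc2c(Cl)ncnc21` is built from the same atoms as compound 1, joined differently; the difference between the two cores is not broken down here. In this assay compound 3 gives 2130 nM, a weaker growth inhibitor than compound 1 and a stronger one than compound 2. Compound 4 `Nc1nc(Cl)c2ncn(Cc3ccccc3CCl)c2n1` stands to compound 3 as compound 2 stands to compound 1: amino in place of hydrogen on an aromatic carbon, at a place described in identical words, so this is the same change. Compound 4 is expected to give about 9000 nM in this assay, with a step of a 4.2-fold higher number from compound 3 to compound 4 (0.63 log units; beyond the scatter) expected, because a 5.4-fold higher number from compound 1 to compound 2 (0.73 log units; beyond the scatter).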

Compound 4, concentration for 50% growth inhibition: 3890 nM
The estimate for compound 4 lay 2.3-fold (0.36 log units) above the measured number, and the stated range covers the measured number.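

In this assay, the step on the second core is a 1.8-fold higher number from compound 3 to compound 4 (0.26 log units; within the scatter), so amino in place of hydrogen gives no clear change in the number there. The size of the step therefore does not carry over from one core to the other, as the two steps side by side show: the same change on two cores in this assay, a 5.4-fold higher number (0.73 log units; beyond the scatter) from compound 1 to compound 2 and a 1.8-fold higher number (0.26 log units; within the scatter) from compound 3 to compound 4, 2.9-fold (0.47 log units) apart, beyond the scatter of two such steps Two pairs show only that the size of this step can differ between these two cores; they do not show what in the cores sets it apart, or how the step would run on a further core.

The compounds shown leave open how a different group at the same place, between two ring nitrogen atoms, would read on each core. A methylamino or a hydroxyl group there could be set beside the amino steps.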